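Notes on an acrylamide series: benzyloxy extension at the aniline

The compounds below may be only part of what the source reports. "The series", "measured", "known", "first", "only" and "open" are said of these compounds alone.

Compound 1 `CN(C)C/C=C/C(=O)Nc1cc2ncnc(Nc3ccc(F)c(Cl)c3)c2cc1O[C@@H]1CCOC1` gives 740 nM in a functional assay on NCI-H1975 cells (Homo sapiens) for antiproliferative activity, read by MTT assay, with a stated time of 72 h; a higher number here means a weaker inhibitor, a lower number a stronger inhibitor. Compound 2 `C=CC(=O)Nc1cc2c(Nc3ccc(F)c(Cl)c3)ncnc2cc1OCc1cn(CCCCC(=O)NO)nn1` gives 2500 nM, and compound 3 `C=CC(=O)Nc1cc2c(Nc3cccc(Cl)c3F)ncnc2cc1OCc1cn(CCCCC(=O)NO)nn1` gives 4180 nM. Among these three numbers compound 2 holds the second highest; its nearest neighbour is compound 3, the step of a 1.7-fold higher number from compound 2 to compound 3 (0.22 log units; within the scatter) lying within the scatter, while its furthest is compound 1, whose number is lower by a margin beyond the scatter.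

Compound 4 `C=CC(=O)Nc1cc2c(Nc3ccc(OCc4cccc(F)c4)c(Cl)c3)ncnc2cc1OCc1cn(CCCCC(=O)NO)nn1` differs from compound 2 by (3-fluorobenzyl)oxy in place of fluoro on an aromatic carbon. Among the compounds with values here, no measured step swaps a fluoro for a (3-fluorobenzyl)oxy; the only step on this aryl amine, a 1.7-fold higher number from compound 2 to compound 3 (0.22 log units; within the scatter), moves a fluoro and stays within the scatter. In this assay the step of no change at the digits printed from compound 2 to compound 4 (within the scatter) is therefore expected to be none beyond the scatter, with wide uncertainty. Compound 4 is estimated at 2500 nM, range 700 nM to 9000 nM.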

Compound 4, half-maximal inhibitory concentration: 14500 nM
Estimate against measurement, compound 4: 5.8-fold (0.76 log units) below; measured number above the stated range.
By their numbers in this assay, from the lowest: compound 1; then compounds 2 and 3 (each within the scatter of the next); then compound 4.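

On the aryl amine, this aromatic carbon, para to a large group and ortho to a chloro group, gives the first change there that lies beyond the scatter in this assay, with a 5.8-fold higher number from compound 2 to compound 4 (0.76 log units; beyond the scatter) as the step. The earlier step on this aryl amine, a 1.7-fold higher number from compound 2 to compound 3 (0.22 log units; within the scatter), did not show this, so (3-fluorobenzyl)oxy in place of fluoro is a real weakening here. No evidence on hand bears on the reason for this step.

As far as these compounds go, whether the benzyl ring, the oxygen link or the ring fluorine carries the step stays open. Also open, from the compounds shown here alone, is how a smaller methoxy group or an amine on this carbon would read.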